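A few compounds are considered here, and "the series" means these few. Any claim that something is new, unique, unknown or untested is made for them only; others in the source may bear on it.

Among the compounds with values here, compound 1, `C/C(=C1/OC(=O)NC1=O)C(c1ccc(-c2ccc3cccc(F)c3c2)[nH]c1=O)C(C)C`, is one of two compounds tested so far in a physicochemical assay for solubility, in phosphate buffer, measured as kinetic solubility; on this read-out lower numbers stand for lower solubility and higher numbers for higher solubility. In this assay compound 1 gives 17200 nM, the lower of the two numbers. The other, compound 2, `CCC(CC)C(/C=C1\OC(=O)NC1=O)c1ccc(-c2ccc3cccc(F)c3c2)[nH]c1=O`, gives 33700 nM in this assay, a difference that stays within the usual scatter, so no real order between the two can be claimed.

Compound 3, `CC(C)C(CC1NC(=O)NC1=O)c1ccc(-c2ccc3cccc(F)c3c2)[nH]c1=O`, has not yet been measured. Its structure differs from compound 1 in one place: a group of 8 heavy atoms (4 carbon, 2 nitrogen, 2 oxygen; one five-membered non-aromatic ring with 2 hetero atoms) in place of a group of 9 heavy atoms (5 carbon, 1 nitrogen, 3 oxygen; one five-membered non-aromatic ring with 2 hetero atoms), on a saturated chain carbon bound to an aromatic carbon and a saturated chain carbon. The new group carries 2 hydrogen-bond donors where the old one carried 1, and one fewer double bond outside aromatic rings. Within the data shown here, no measured pair shows a change of this kind. Among the measured compounds shown here, no step can be read from the numbers so far. A modest rise in this assay is expected, with the step from compound 1 to compound 3 estimated at a 2.3-fold higher number from compound 1 to compound 3 (0.37 log units; beyond the scatter). For compound 3 the expected solubility is 40000 nM, within a range from 15000 nM to 100000 nM.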

Compound 3, solubility: 12300 nM
Compound 3: middle estimate off by 3.3-fold (0.51 log units), on the high side; the whole stated range lies above it.
By their numbers in this assay, from the lowest: compounds 3, 1 and 2 (each within the scatter of the next, the first and the last beyond it).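

On the saturated chain carbon bound to an aromatic carbon and a saturated chain carbon, the (2,5-dioxoimidazolidin-4-yl)methyl group replaces the earlier group, and this assay gives a 1.4-fold lower number from compound 1 to compound 3 (0.15 log units; within the scatter). Within the data shown here, this is the first step that can be read at this position, and it shows that exchanging one group holding a five-membered non-aromatic ring for the other leaves the two compounds indistinguishable on this read-out. Nothing measured here offers an explanation for this outcome.

From the compounds shown here alone, it remains open whether a carboxylic acid or an amine at the same place would move the number beyond the usual scatter. Going by these compounds, it is also open whether the (2,5-dioxoimidazolidin-4-yl)methyl group would give a similar step on the side chain of compound 2.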